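A few compounds are considered here, and "the series" means these few. Any claim that something is new, unique, unknown or untested is made for them only; others in the source may bear on it.

Measured compounds in a functional assay for agonist activity at Bile acid receptor (Homo sapiens), read by a luciferase reporter; on this read-out lower numbers stand for an effect already at smaller amounts and higher numbers for an effect only at larger amounts of compound:

Compound 1, `O=C(O)Cc1ccc(NC(=O)C(C2CCCCC2)n2c(-c3ccc(Cl)cc3)nc3cc(F)c(F)cc32)cc1`: 4900 nM
Compound 2, `O=C(O)CCc1ccc(NC(=O)C(C2CCCCC2)n2c(-c3ccc(Cl)cc3)nc3cc(F)c(F)cc32)cc1`: 2000 nM

Compound 2 gives the lowest of the two numbers; its nearest neighbour is compound 1, and the step of a 2.5-fold lower number from compound 1 to compound 2 (0.39 log units; beyond the scatter) lies beyond the scatter. That step changes only the chain between the ring and the acid, carboxymethyl in place of carboxy on a saturated chain carbon bound to an aromatic carbon.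

Compound 3, `Cc1nc(NC(=O)C(C2CCCCC2)n2c(-c3ccc(Cl)cc3)nc3cc(F)c(F)cc32)sc1C(=O)O`, is not yet measured. It differs from compound 2 by 5-carboxy-4-methyl-1,3-thiazol-2-yl in place of 4-(2-carboxyethyl)phenyl on an amide-type nitrogen. The acid group is kept, but the ring that carries it and the spacer to the acid change together. For the measured compounds named here, the only measured step, from compound 1 to compound 2, speaks to the distance between acid and ring and gave a modest shift; it does not cover exchange of the ring itself, so it bears on the present step only loosely, and nothing here covers a thiazole in this position.

For compound 3 the estimate is therefore held close to compound 2, with a wide range: 3000 nM, between 600 nM and 15000 nM, a step of a 1.5-fold higher number from compound 2 to compound 3 (0.18 log units; within the scatter) expected, which is no firm direction beyond the scatter.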

Compound 3, half-maximal effective concentration: 10400 nM
For compound 3 the middle estimate is 3.5-fold (0.54 log units) below the measured one; the range from low to high includes it.
By their numbers in this assay, from the lowest: compound 2; then compound 1; then compound 3.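

In this assay, 5-carboxy-4-methyl-1,3-thiazol-2-yl in place of 4-(2-carboxyethyl)phenyl on the amide-type nitrogen gives a 5.2-fold higher number from compound 2 to compound 3 (0.72 log units; beyond the scatter), so this position responds to a change of the whole acid-bearing ring group, whereas the earlier step, a 2.5-fold lower number from compound 1 to compound 2 (0.39 log units; beyond the scatter), covered only the chain to the acid. Against 4-(carboxymethyl)phenyl, the same thiazole group gives a 2.1-fold higher number from compound 1 to compound 3 (0.33 log units; beyond the scatter), so among the three compounds, both phenyl acids give lower numbers than the thiazole acid. No measurement shown accounts for these differences.

The change from compound 2 to compound 3 replaces the ring, adds the methyl group and shortens the link to the acid all at once, so the share of each remains unresolved. Still open, from the compounds shown here alone, is how a thiazole without the methyl group, a thiazole carrying a carboxyethyl chain, a longer chain on the phenyl ring, or a tetrazole or primary amide in place of the carboxylic acid would read out in this assay.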